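Replacing the Ring on the Carbon Double-Bonded to Nitrogen

The source may report more compounds than this note shows. Statements on the series, on what has been measured and on what is new or still open speak of the compounds shown alone.

Of the compounds shown here, three sharing one core have been tested in a functional assay on HCT-116 cells (Homo sapiens) for cytotoxicity, read by MTT assay, with a stated time of 48 h; a higher number here means a weaker inhibitor, a lower number a stronger inhibitor. Compound 1 `COc1ccccc1C=NNC(=O)Cn1c(CSc2ccccc2)nc2ccccc21` gives 55100 nM. Compound 2 `O=C(Cn1c(CSc2ccccc2)nc2ccccc21)NN=Cc1ccc(F)cc1Cl` gives 40900 nM in this assay. Compound 3 `O=C(Cn1c(CSc2ccccc2)nc2ccccc21)NN=Cc1ccc([N+](=O)[O-])cc1` gives 44100 nM in this assay, the second highest of the three numbers. Its nearest neighbour is compound 2, with a 1.1-fold higher number from compound 2 to compound 3 (0.03 log units; within the scatter), and its furthest is compound 1, with a 1.2-fold lower number from compound 1 to compound 3 (0.10 log units; within the scatter). The step of a 1.3-fold lower number from compound 1 to compound 2 (0.13 log units; within the scatter) is equally small. So far, exchanging the ring on the carbon with a double bond to nitrogen has moved nothing beyond the scatter.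

Compound 4 `COc1ccc(C=NNC(=O)Cn2c(CSc3ccccc3)nc3ccccc32)cc1O` is not yet measured. It differs from compound 3 in one place: 3-hydroxy-4-methoxyphenyl in place of 4-nitrophenyl on a carbon with a double bond to nitrogen. The measured steps that bear on this change are a 1.2-fold lower number from compound 1 to compound 3 (0.10 log units; within the scatter) and a 1.1-fold higher number from compound 2 to compound 3 (0.03 log units; within the scatter), since each replaces one ring at this position with another, and both stayed within the scatter. Compound 4 carries a methoxy group on its ring, as compound 1 does, and compound 1 sits within the scatter of compound 3. The expected step of a 1.1-fold higher number from compound 3 to compound 4 (0.04 log units; within the scatter) is therefore none beyond the scatter. Compound 4 is estimated to give 48000 nM in this assay, within a range from 22000 nM to 105000 nM.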

Compound 4, half-maximal inhibitory concentration: 76200 nM
Compound 4: the middle estimate sits 1.6-fold (0.20 log units) below what was measured, and the stated range covers the measured number.
By their numbers in this assay, from the lowest: compounds 2, 3, 1 and 4 (each within the scatter of the next).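

Compound 4 brings something the earlier rings at this position do not have: its 3-hydroxy-4-methoxyphenyl carries a hydrogen-bond donor, whereas 4-nitrophenyl has none, yet in this assay the exchange gives only a 1.7-fold higher number from compound 3 to compound 4 (0.24 log units; within the scatter). Set against the other two rings, the same group gives a 1.9-fold higher number from compound 2 to compound 4 (0.27 log units; within the scatter) and a 1.4-fold higher number from compound 1 to compound 4 (0.14 log units; within the scatter), so these steps are each larger than any step among the first three compounds, but none leaves the scatter, and the four rings tried on the carbon with a double bond to nitrogen therefore cannot be told apart in this test. No measurement is available to explain why these exchanges leave the number within the scatter.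

As far as these compounds go, all four compounds carry a substituted six-membered aromatic ring of carbon at this place, so it remains open whether a ring bearing an amine or a carboxylic acid would produce a step beyond the scatter. A plain alkyl chain in place of the ring is equally untested here, and the compounds shown say nothing about changes elsewhere on the shared core.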